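Methoxy replaces methyl on the chain of compound 2

The source may hold more compounds than are shown below. What is called first, only, known or untested is meant among the compounds shown, and "the series" means these compounds.

The measured compounds:
compound 1 `Nc1ccc(-c2cc(=O)c3c(N)c(F)cc(F)c3o2)cc1F`, 40 nM
compound 2 `CCc1c(F)c(N)c2c(=O)cc(-c3ccc(N)c(F)c3)oc2c1F`, 130 nM
compound 3 `CN(C)CC(=O)OCc1c(F)c(N)c2c(=O)cc(-c3ccc(N)c(F)c3)oc2c1F`, 26 nM

In a functional assay on MCF7 cells (Homo sapiens) for cytotoxicity, read by neutral red uptake, with a stated time of 3 days (on this read-out lower numbers stand for stronger inhibition and higher numbers for weaker inhibition), compound 2 gives the highest of the three numbers. Its nearest neighbour is compound 1, with a step of a 3.3-fold higher number from compound 1 to compound 2 (0.51 log units; beyond the scatter); the furthest is compound 3, with a step of a 5.0-fold lower number from compound 2 to compound 3 (0.70 log units; beyond the scatter). Compound 4 `COCc1c(F)c(N)c2c(=O)cc(-c3ccc(N)c(F)c3)oc2c1F` is not yet measured. It differs from compound 2 in one place: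
methoxy in place of methyl on a saturated chain carbon bound to an aromatic carbon

Within the data shown here, two measured steps bear on this change. The step of a 3.3-fold higher number from compound 1 to compound 2 (0.51 log units; beyond the scatter) shows that adding ethyl to the shared core raised the number beyond the scatter. The step of a 5.0-fold lower number from compound 2 to compound 3 (0.70 log units; beyond the scatter) shows that exchanging the outer methyl of that ethyl for an oxygen-bearing group lowered the number beyond the scatter. Among the measured compounds shown here, compound 4 carries a smaller oxygen-bearing group in the same place, so the number is expected to move down from compound 2, though with only one such step to go on the size is uncertain. Compound 4 is therefore estimated at 55 nM in this assay, in a range of 22 nM to 140 nM, which means an expected step of a 2.4-fold lower number from compound 2 to compound 4 (0.37 log units; beyond the scatter).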

Compound 4, half-maximal inhibitory concentration: 46 nM
Compound 4: middle estimate off by 1.2-fold (0.08 log units), on the high side; the measured number falls inside the stated range.
By their numbers in this assay, from the lowest: compounds 3, 1 and 4 (each within the scatter of the next); then compound 2.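

In this assay the step of a 2.8-fold lower number from compound 2 to compound 4 (0.45 log units; beyond the scatter) shows that an oxygen in the chain on this aromatic carbon is enough to lower the number, without the ((dimethylamino)methyl)carbonyl group that compound 3 carries on that oxygen. That larger group brings no readable gain here: putting methyl in its place gives a 1.8-fold higher number from compound 3 to compound 4 (0.25 log units; within the scatter) and so no change that can be told apart. The methoxymethyl group also stands level with the plain hydrogen of compound 1, with a 1.2-fold higher number from compound 1 to compound 4 (0.06 log units; within the scatter) as the step, so among the groups shown on this aromatic carbon only the ethyl of compound 2 sets the number apart from the others.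

The compounds shown leave open how a hydroxymethyl group, a longer ether chain such as ethoxymethyl, or an aminomethyl group would read on this aromatic carbon, and whether a plain methyl there would read like ethyl or like hydrogen. Nothing at hand explains why the ethyl compound differs from the compounds with an oxygen in the chain.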